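This account rests on a few compounds, and the source may have more. Where it says the series, first, only, none or still open, it means among the compounds named here.

Measured compounds:
compound 1 `O=C(O)CCn1c(=O)oc2cc(OCC3CCC3)c(Cl)cc21` 25.1 nM
compound 2 `CCc1cc2oc(=O)n(CCC(=O)O)c2cc1Cl` 10 nM

Going by the values given here, in an assay for inhibition of kynurenine 3-monooxygenase (Homo sapiens), read by mass spectrometry, with a stated time of 1 h (on this read-out lower numbers stand for stronger inhibition and higher numbers for weaker inhibition), compound 2 gives the lowest of the two numbers; the single measured step, a 2.5-fold lower number from compound 1 to compound 2 (0.40 log units; beyond the scatter), lies beyond the scatter. Compound 3 `O=C(O)CCn1c(=O)oc2cc(OCc3ccccc3)c(Cl)cc21` differs from compound 2 by benzyloxy in place of ethyl on an aromatic carbon. Among the compounds with values here, only that step bears on the change, and it ran the other way, because a 2.5-fold lower number from compound 1 to compound 2 (0.40 log units; beyond the scatter) shows that replacing cyclobutylmethoxy by ethyl lowered the number. As benzyloxy resembles cyclobutylmethoxy more than ethyl, a modest rise back toward compound 1 is expected for compound 3, a 2.5-fold higher number from compound 2 to compound 3 (0.40 log units; beyond the scatter). Compound 3 is estimated at 25 nM, within 8 nM to 80 nM.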

Compound 3, half-maximal inhibitory concentration: 25.1 nM
Beside the measured number, compound 3's estimate is 1.0-fold (0.00 log units) below it, and the stated range covers the measured number.
By their numbers in this assay, from the lowest: compound 2; then compounds 1 and 3 (each within the scatter of the next).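

In this assay, at the position ortho to a chloro group, exchanging the ring at the end of the side chain gives no change at the digits printed from compound 1 to compound 3 (within the scatter), so cyclobutyl and phenyl are not told apart here. Ethyl stands apart from benzyloxy as well as from cyclobutylmethoxy, with a 2.5-fold higher number from compound 2 to compound 3 (0.40 log units; beyond the scatter), so among these compounds the higher number does not depend on an aromatic ring in the entering group. No measurement available here gives a reason for either step.

On these data alone, whether the oxygen or the length of the group separates these compounds from compound 2 remains open. Methoxy and a propyl chain at this position would bear on that question.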